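A few compounds are considered here, and "the series" means these few. Any claim that something is new, unique, unknown or untested is made for them only; others in the source may bear on it.

For the measured compounds named here, in a functional assay on A549 cells (Homo sapiens) for antiproliferative activity, read by MTT assay, with a stated time of 48 h (a lower number here means a stronger inhibitor, a higher number a weaker inhibitor), the three compounds tested so far give only one number. Compound 1 `COc1ccc(-c2cncc3[nH]c(=O)n(Cc4cc(OC)c(OC)c(OC)c4)c23)cc1O` reports only a limit of the assay, > 20000 nM. Compound 2 `COc1ccc(-c2nc3cnccc3n2-c2cc(OC)c(OC)c(OC)c2)cc1O` also reports only a limit, > 20000 nM. Compound 3 `COc1ccc(-c2cc3c(cn2)[nH]c(=O)n3-c2cc(OC)c(OC)c(OC)c2)cc1F` is the only one of the three with a measured number, at 2020 nM.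

Compound 4 `COc1ccc(-c2cc3c(cn2)[nH]c(=O)n3-c2cc(OC)c(OC)c(OC)c2)cn1` shares its core with compound 3 and differs in one place. It carries 6-methoxypyridin-3-yl in place of 3-fluoro-4-methoxyphenyl on an aromatic carbon next to the ring nitrogen (6-methoxypyridin-3-yl in place of 3-fluoro-4-methoxyphenyl on an aromatic carbon). Going by the values given here, no pair of measured compounds shows a change of this kind, so the expectation rests on compound 3 at 2020 nM alone. A moderate weakening in this assay is expected, though a result within the usual scatter would not be surprising. The estimated change is a 2.0-fold higher number from compound 3 to compound 4 (0.30 log units; within the scatter). Compound 4 is expected to give about 4000 nM, with an estimated range from 1200 nM to 15000 nM.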

Compound 4, half-maximal inhibitory concentration: 1220 nM
The estimate for compound 4 lay 3.3-fold (0.52 log units) above the measured number, and the stated range covers the measured number.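

In this assay, putting 6-methoxypyridin-3-yl in place of 3-fluoro-4-methoxyphenyl gives a 1.7-fold lower number from compound 3 to compound 4 (0.22 log units; within the scatter) at this position, on an aromatic carbon next to the ring nitrogen. This step shows that the position accepts a ring with 1 hetero atom and no fluorine without leaving the scatter, so the change neither gains nor loses anything that can be told apart. For the compounds shown here, it remains the only step that can be read, as the values of compound 1 and compound 2 are limits: the limit of > 20000 nM in this assay, at which 2 of the 4 values shown sit.

On these data alone, what an amine such as morpholine or a carboxylic acid would do on this aromatic carbon stays open. So does the role of the methoxy group on the pyridine ring, as no compound shown carries an ethoxy or a hydroxy group there.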